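Amine Swap at the End of the Propoxy Chain

A few compounds are considered here, and "the series" means these few. Any claim that something is new, unique, unknown or untested is made for them only; others in the source may bear on it.

Compound 1 `CCN(CC)CCCOc1cc2ncnc(Nc3nc4ccc(C(=O)Nc5c(C)cccc5C)cc4s3)c2cc1OC` gives 28400 nM in a functional assay on K562 cells (Homo sapiens) for cytotoxicity, read by WST assay, with a stated time of 72 h; on this read-out lower numbers stand for stronger inhibition and higher numbers for weaker inhibition.
Compound 2 `COc1cc2c(Nc3nc4ccc(C(=O)Nc5c(C)cc(C)cc5C)cc4s3)ncnc2cc1OCCCN1CCCCC1C` gives 3500 nM in this assay.
Compound 3 `CCN(CC)CCCOc1cc2ncnc(Nc3nc4ccc(C(=O)Nc5c(C)cc(C)cc5C)cc4s3)c2cc1OC` gives 6800 nM in this assay.

Among these three numbers compound 3 stands second highest. Its nearest neighbour is compound 2, separated by a gap that lies within the scatter, and its furthest is compound 1, separated by a gap that lies beyond it. Compound 4 `COc1cc2c(Nc3nc4ccc(C(=O)Nc5c(C)cc(C)cc5C)cc4s3)ncnc2cc1OCCCN1CCCCC1` differs from compound 3 by piperidin-1-yl in place of diethylamino on a saturated chain carbon, three bonds along the chain from an oxygen on an aromatic ring. Among the compounds with values here, only one of the measured steps touches this part of the molecule: the exchange of a cyclic amine for the open-chain one, a 1.9-fold higher number from compound 2 to compound 3 (0.29 log units; within the scatter), stayed within the scatter. The other step, a 4.2-fold lower number from compound 1 to compound 3 (0.62 log units; beyond the scatter), concerns the aryl amide and offers no guidance for the amine. Because a 1.9-fold higher number from compound 2 to compound 3 (0.29 log units; within the scatter) produced no movement beyond the scatter, compound 4 is expected to stay close to compound 3, with an estimated step of a 1.4-fold lower number from compound 3 to compound 4 (0.15 log units; within the scatter). Compound 4 is therefore estimated at 4800 nM in this assay, with a range from 1900 nM to 12000 nM.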

Compound 4, half-maximal inhibitory concentration: 9300 nM
Compound 4: the middle estimate sits 1.9-fold (0.29 log units) below what was measured; the measured number falls inside the stated range.
By their numbers in this assay, from the lowest: compounds 2, 3 and 4 (each within the scatter of the next, the first and the last beyond it); then compound 1.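

Replacing diethylamino with piperidin-1-yl on the saturated chain carbon, three bonds along the chain from the oxygen on the aromatic ring, gives a 1.4-fold higher number from compound 3 to compound 4 (0.14 log units; within the scatter) in this assay, so the plain ring and the open-chain amine cannot be told apart here. Within the data shown here, the new compound also gives the first step beyond the scatter at this end of the molecule, as hydrogen in place of methyl on a saturated ring carbon gives a 2.7-fold higher number from compound 2 to compound 4 (0.42 log units; beyond the scatter), though this step is modest and rests on a single pair, and compound 3 lies within the scatter of both ring compounds. No measurement offered here accounts for the effect of this methyl or for the behaviour of the amines.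

The compounds shown leave open how a morpholine, a pyrrolidine or a 4-methylpiperazine at the end of the chain would read, and whether a shorter or longer chain would keep these numbers. They also leave open whether the step from the ring methyl would recur with the aryl amide of compound 1, since all the amine comparisons share the aryl amide of compound 3.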